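Swapping the Hydroxyl for a Phenyl Ring

The compounds below may be only part of what the source reports. "The series", "measured", "known", "first", "only" and "open" are said of these compounds alone.

Going by the values given here, compound 2 `Oc1ccc2oc(Cc3ccccc3)cc2c1CN1CCC(O)CC1` holds the lowest number of the two compounds measured so far in a functional assay on SQ20B cells (Homo sapiens) for cytotoxicity, read by MTT assay, with a stated time of 72 h; a lower number here means a stronger inhibitor, a higher number a weaker inhibitor; compound 2 gives 13000 nM. The other, compound 1 `CON(C)Cc1c(O)ccc2oc(Cc3ccccc3)cc12`, carries a different amine on the same saturated chain carbon, and in this assay compound 1 gives 40000 nM; the step of a 3.1-fold lower number from compound 1 to compound 2 (0.49 log units; beyond the scatter) separates them. Compound 3 `Oc1ccc2oc(Cc3ccccc3)cc2c1CN1CCC(c2ccccc2)CC1` keeps the whole framework of compound 2 and changes one piece: phenyl in place of hydroxy on a saturated ring carbon. Among the compounds with values here, no measured step involves this kind of change, since the only step available, a 3.1-fold lower number from compound 1 to compound 2 (0.49 log units; beyond the scatter), swaps one amine for another rather than a group on a saturated ring carbon. The expectation therefore rests on the structural change alone, and a modest step toward a lower number is expected, a 2.6-fold lower number from compound 2 to compound 3 (0.41 log units; beyond the scatter). Compound 3 is estimated at 5000 nM in this assay, with a range from 1500 nM to 20000 nM.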

Compound 3, half-maximal inhibitory concentration: > 200000 nM
Compound 3 gave a limit, no number; the forecaster's own chance of this, stated with the estimate: 10%; middle value at least 40-fold (1.60 log units) away from the limit.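

On the saturated ring carbon, three ring bonds from the ring nitrogen, the group present matters greatly in this assay: the change to phenyl in place of hydroxy gives an at least 15-fold higher number from compound 2 to compound 3 (1.18 log units; beyond the scatter). The earlier step altered only the amine as a whole, so it said nothing about this ring carbon, and this step is much larger than a 3.1-fold lower number from compound 1 to compound 2 (0.49 log units; beyond the scatter). Compound 3 gave no exact number, only a limit, so the true size of the step stays unknown: the limit of > 200000 nM in this assay, at which 1 of the 3 values shown sits.

Because hydroxy leaves and phenyl enters in the same step, the compounds shown leave open whether the weaker result follows from the loss of one or the arrival of the other. A methyl, a methoxy or an amino group on that same ring carbon would help separate these two possibilities.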